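A few compounds are considered here, and "the series" means these few. Any claim that something is new, unique, unknown or untested is made for them only; others in the source may bear on it.

Measured in a functional assay on A549 cells (Homo sapiens) for inhibition, read by sulforhodamine B assay, with a stated time of 48 h; on this read-out higher numbers stand for weaker inhibition of growth and lower numbers for stronger inhibition of growth:

compound 1 `Nc1cc(N)c2nc(-c3ccccc3)c(Oc3ccc(Cl)c(Cl)c3)nc2c1` gives 18200 nM
compound 2 `COc1cc(CNc2nc3cc(N)cc(N)c3nc2-c2ccccc2)cc(OC)c1OC` gives 4270 nM
compound 3 `CCOC(=O)[C@H](CCC(=O)O)NC(=O)c1ccc(Oc2nc3cc(N)cc(N)c3nc2-c2ccccc2)cc1` gives < 100000 nM, which is a limit of the assay and not a number.

Of the two numbers, compound 1 stands highest; the value of compound 2 is the lower one, and the gap between them lies beyond the usual scatter. For compound 3 only a limit is reported, (the limit of < 100000 nM in this assay, at which 1 of the 3 values shown sits), so it cannot be ranked against the others.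

Compound 4 `Nc1cc(N)c2nc(-c3ccccc3)c(NCc3ccc(F)cc3)nc2c1` has not yet been measured in this assay. It differs from compound 1 in one place: (4-fluorobenzyl)amino in place of 3,4-dichlorophenoxy on an aromatic carbon. The shared core is kept; the aryl ether is exchanged for a benzylamine. Compound 2, which carries a substituted benzylamino group in the same place, gives 4270 nM, a lower number than compound 1. On that single comparison the step from compound 1 to compound 4 is expected to run toward a lower number, a 3.0-fold lower number from compound 1 to compound 4 (0.48 log units; beyond the scatter), of a size roughly like the gap between compound 1 and compound 2, though one pair is a thin basis. The estimate for compound 4 is 6000 nM, with a range from 2000 nM to 20000 nM.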

Compound 4, concentration for 50% growth inhibition: 17800 nM
Estimate against measurement, compound 4: 3.0-fold (0.47 log units) below; the measured number falls inside the stated range.
By their numbers in this assay, from the lowest: compound 2; then compounds 4 and 1 (each within the scatter of the next).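

In this assay, the exchange at this aromatic carbon, next to the ring nitrogen and ortho to a phenyl group, reads as a 1.0-fold lower number from compound 1 to compound 4 (0.01 log units; within the scatter), so (4-fluorobenzyl)amino, with a hydrogen-bond donor that 3,4-dichlorophenoxy lacks, cannot be told apart from the aryl ether at this place on this read-out. A benzylamino group at this place therefore does not by itself bring the lower number: compound 4, with its 4-fluorobenzyl group, gives 17800 nM, and compound 2, with its 3,4,5-trimethoxybenzyl group, gives 4270 nM. No measured property among the data shown bears on this result.

Compound 3 gives < 100000 nM, which is a limit of the assay and not a number, so the aryl ether carrying its amide and carboxylic acid adds nothing to this comparison. Open, on these data alone, is whether the methoxy groups alone set compound 2 apart, which an unsubstituted benzylamino group or a single 4-methoxybenzylamino group would test, and whether a longer chain such as phenethylamino or a morpholine at this place would separate from compound 1.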